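The compounds below may be only part of what the source reports. "The series", "measured", "known", "first", "only" and "open" are said of these compounds alone.

Working notes on the series. Compound 3 `CC(C)(C)c1ccc(C(=O)N2CCC3(CC2)C(=O)N(CC(=O)NCCC(=O)O)CN3c2ccccc2)cc1` stands second highest of the three numbers in an assay on HEK293 cells for displacement of a labelled ligand from NPC1-like intracellular cholesterol transporter 1 (Homo sapiens) (a lower number here means a stronger inhibitor, a higher number a weaker inhibitor), where compound 3 gives 11400 nM. Its nearest neighbour is compound 1 `CC(C)(C)c1ccc(C(=O)N2CCC3(CC2)C(=O)N(CC(=O)N2CCCC(C(N)=O)C2)CN3c2ccccc2)cc1`, for which compound 1 gives 16900 nM, and the pair a 1.5-fold lower number from compound 1 to compound 3 (0.17 log units; within the scatter) lies within the scatter. The furthest is compound 2 `CCOC(=O)C1CCN(C(=O)CN2CN(c3ccccc3)C3(CCN(C(=O)c4ccc(C(C)(C)C)cc4)CC3)C2=O)CC1`, for which compound 2 gives 3100 nM, a modest step of a 3.7-fold higher number from compound 2 to compound 3 (0.57 log units; beyond the scatter) beyond the scatter; the related pair a 5.5-fold lower number from compound 1 to compound 2 (0.74 log units; beyond the scatter) points the same way.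

The next compound is compound 4 `CC1(C)CC(OC(=O)CN2CN(c3ccccc3)C3(CCN(C(=O)c4ccc(C(C)(C)C)cc4)CC3)C2=O)CC(C)(C)N1`. Its change from compound 3 is (2,2,6,6-tetramethylpiperidin-4-yl)oxy in place of (2-carboxyethyl)amino on a carbonyl carbon. Among the compounds with values here, no measured step covers this exact replacement. Within the data shown here, the steps that bear on it are the two modest ones, a 5.5-fold lower number from compound 1 to compound 2 (0.74 log units; beyond the scatter) and a 3.7-fold higher number from compound 2 to compound 3 (0.57 log units; beyond the scatter), both of which show that exchanging the group on this carbonyl carbon can move the number by a modest amount. A modest step downward in this assay is therefore expected for compound 4, a 2.5-fold lower number from compound 3 to compound 4 (0.40 log units; beyond the scatter), though a result within the scatter cannot be ruled out. Compound 4 is estimated at 4500 nM, with a range from 1500 nM to 13000 nM.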

Compound 4, half-maximal inhibitory concentration: 1300 nM
For compound 4 the middle estimate is 3.5-fold (0.54 log units) above the measured one, and the stated range ends above it.
By their numbers in this assay, from the lowest: compound 4; then compound 2; then compounds 3 and 1 (each within the scatter of the next).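

The (2,2,6,6-tetramethylpiperidin-4-yl)oxy group is the only one here attached to this carbonyl carbon through oxygen rather than nitrogen, and compound 4 has the lowest number of the four in this assay, with a 2.4-fold lower number from compound 2 to compound 4 (0.38 log units; beyond the scatter) and an 8.8-fold lower number from compound 3 to compound 4 (0.94 log units; beyond the scatter). Within the data shown here, the position can therefore move the number further than the earlier modest steps showed, as a 13-fold lower number from compound 1 to compound 4 (1.11 log units; beyond the scatter) is the only large step so far. Nothing measured here accounts for the shift.

Going by these compounds, the oxygen link and the tetramethylpiperidine ring enter together, so it remains open which of them goes with the lower number. A (2,2,6,6-tetramethylpiperidin-4-yl)amino group or a plain piperidin-4-yloxy group on this carbonyl carbon would separate the two.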